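Amide in place of sulfonamide on the propoxy linker

The compounds below may be only part of what the source reports. "The series", "measured", "known", "first", "only" and "open" are said of these compounds alone.

Three compounds of one shared core were measured in a functional assay on PANC-1 cells (Homo sapiens) for inhibition, read by MTT assay, with a stated time of 24 h, tested at 10 uM; a lower number here means less inhibition, a higher number more inhibition at the concentration tested (going by the name of the read-out). Compound 1 `COc1ccc(C(=O)NCCCOc2cc(=O)n(CCCO)c3c2CC(CC=C(C)C)C(C)(C)C3)cc1` gives 55.5%. Compound 2 `CC(C)=CCC/C(C)=C/CC1Cc2c(OCCCNS(=O)(=O)c3ccc(Br)cc3)cc(=O)n(CCCO)c2CC1(C)C` gives 15.2%, and compound 3 `CC(C)=CCC/C(C)=C/CC1Cc2c(OCCCNS(=O)(=O)c3ccc([N+](=O)[O-])cc3)cc(=O)n(CCCO)c2CC1(C)C` gives 7.4%. Compound 3 thus stands lowest of the three numbers, with compound 2 nearest and compound 1 furthest. Going by the values given here, the only single step measured so far, a number 7.8 percentage points lower from compound 2 to compound 3 (within the scatter), lies within the scatter and concerns the aromatic substituent, not the linker.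

Compound 4 `COc1ccc(C(=O)NCCCOc2cc(=O)n(CCCO)c3c2CC(C/C=C(\C)CCC=C(C)C)C(C)(C)C3)cc1` is not yet measured. It differs from compound 3 in one place: (4-methoxyphenyl)carbonyl in place of (4-nitrophenyl)sulfonyl on an amine nitrogen. Among the compounds with values here, no measured step addresses this exchange directly. Compound 1 carries the same (4-methoxyphenyl)carbonyl group on a shorter chain and gives 55.5%, far above compound 3; compounds 1 and 3 differ in two places, so only their two values can be compared. On that basis compound 4 is expected to move upward by a number 42.6 percentage points higher from compound 3 to compound 4 (beyond the scatter) in this assay. The estimate for compound 4 is 50%, expected to fall between 30% and 70%.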

Compound 4, a percentage reported as inhibition, at one concentration (the size of the read-out at that concentration, not a potency): 45.7%
Compound 4: middle estimate off by 4.3 percentage points, on the high side; the measured number falls inside the stated range.
By their numbers in this assay, from the lowest: compounds 3 and 2 (each within the scatter of the next); then compounds 4 and 1 (each within the scatter of the next).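

In this assay the exchange on the amine nitrogen can now be read directly on one side chain: (4-methoxyphenyl)carbonyl in place of (4-nitrophenyl)sulfonyl gives a number 38.3 percentage points higher from compound 3 to compound 4 (beyond the scatter), and in place of (4-bromophenyl)sulfonyl it gives a number 30.5 percentage points higher from compound 2 to compound 4 (beyond the scatter). The side chain shows no such separation, as 3-methylbut-2-en-1-yl in place of hydrogen on a saturated chain carbon bound to a double-bonded chain carbon gives a number 9.8 percentage points lower from compound 1 to compound 4 (within the scatter), so the large steps here belong to the group on the amine nitrogen. Nothing available explains why this exchange has so large an effect.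

The compounds shown leave open whether the carbonyl or the methoxy group carries the step. A (4-methoxyphenyl)sulfonyl group or a (4-nitrophenyl)carbonyl group on the same nitrogen would separate the two.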